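A few compounds are considered here, and "the series" means these few. Any claim that something is new, unique, unknown or untested is made for them only; others in the source may bear on it.

Compound 3 `Cc1c(OCCCCOc2cccc(C(=O)O)c2)ccc(C(=O)CC(C)C)c1C` sits lowest of the three compounds measured in an assay on HEK293 cells for positive allosteric modulation of metabotropic glutamate receptor 2 (Rattus norvegicus), read by thallium flux, with a stated time of 2.5 min; on this read-out lower numbers stand for smaller maximal responses and higher numbers for larger maximal responses: compound 3 gives 12.1%, compound 2 `COC(=O)c1ccc(OCCCCOc2ccc(C(=O)CC3CCCC3)c(C)c2C)cc1` gives 14.1%, a number within the scatter of compound 3, and compound 1 `Cc1c(OCCCCOc2ccccc2C(=O)O)ccc(C(=O)CC2CCCC2)c1C` gives 67.1%, well beyond it. Compound 4 `Cc1c(OCCCCOc2cccc(C(=O)O)c2)ccc(C(=O)CC2CCCC2)c1C` differs from compound 3 in one place: cyclopentyl in place of isopropyl on a saturated chain carbon bound to a carbonyl carbon. Within the data shown here, the only single-place step measured, a number 53 percentage points lower from compound 1 to compound 2 (beyond the scatter), concerns the acid-bearing ring, not this part, so no measured step bears directly on the change. Compound 1 also carries the cyclopentyl group and reads high, but it differs from compound 3 in the acid position as well, so its value is a weak hint. A modest rise, a number 12.9 percentage points higher from compound 3 to compound 4 (beyond the scatter), is expected. Compound 4 is estimated at 25%, between 8% and 55%.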

Compound 4, largest response reached (reported as percent of maximum), in percent of the reference or control that the assay uses: 22.4%
For compound 4 the middle estimate is 2.6 percentage points above the measured one; the measured number falls inside the stated range.
By their numbers in this assay, from the lowest: compounds 3, 2 and 4 (each within the scatter of the next, the first and the last beyond it); then compound 1.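

In this assay, among these compounds, cyclopentyl in place of isopropyl on the saturated chain carbon bound to a carbonyl carbon brings a modest gain (a number 10.3 percentage points higher from compound 3 to compound 4 (beyond the scatter)), the first direct reading of this change. With cyclopentyl held fixed, 3-carboxyphenyl in place of 2-carboxyphenyl has a much larger effect (a number 44.7 percentage points lower from compound 1 to compound 4 (beyond the scatter)), so the high reading goes with 2-carboxyphenyl, not cyclopentyl alone, while 3-carboxyphenyl and 4-(methoxycarbonyl)phenyl cannot be told apart (a number 8.3 percentage points higher from compound 2 to compound 4 (within the scatter)). Nothing available explains these differences.

As far as these compounds go, whether cyclopentyl gives the same gain alongside 2-carboxyphenyl remains open, as does how cyclohexyl or tert-butyl would read at this position.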